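This account rests on a few compounds, and the source may have more. Where it says the series, first, only, none or still open, it means among the compounds named here.

Compound 3 `Cc1nc2ccccc2n1Cc1ccc(C(=O)NO)cc1` gives 7900 nM in an ADME assay on Huh-7 cells (Homo sapiens) for cytotoxicity, read by MTT assay, with a stated time of 3 days; a higher number here means that more compound is tolerated, a lower number that less compound is tolerated. Of the two numbers shown, compound 3 stands at the higher one, yet compound 1 `CCCNNC(=O)CCCCCCC(=O)Nc1ccccc1` gives 7000 nM, a gap within the scatter, so the two cannot be told apart. Compound 2 `CCNNC(=O)c1ccccc1` reaches only a limit of this assay, > 1000000 nM, not a number. Compound 4 `CCCNNC(=O)c1ccc(Cn2c(C)nc3ccccc32)cc1` differs from compound 3 in one place: propylamino in place of hydroxy on an amide-type nitrogen. Among the measured compounds shown here, no measured pair shares this change, so its size is not known from measurement. Compound 1 also carries propylamino on an amide-type nitrogen and gives 7000 nM, close to compound 3. The step of a 1.1-fold higher number from compound 3 to compound 4 (0.06 log units; within the scatter) is therefore expected to stay within the scatter. Compound 4 is estimated at 9000 nM, ranging from 3000 nM to 40000 nM.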

Compound 4, half-maximal cytotoxic concentration: 9900 nM
The estimate for compound 4 lay 1.1-fold (0.04 log units) below the measured number; the measured number falls inside the stated range.
By their numbers in this assay, from the lowest: compounds 1, 3 and 4 (each within the scatter of the next). At a limit, above all of these: compound 2.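

Putting propylamino in place of hydroxy on an amide-type nitrogen gives a 1.3-fold higher number from compound 3 to compound 4 (0.10 log units; within the scatter) in this assay. Among the compounds shown here, this is the first measured pair for this change, and it shows that the cytotoxicity seen with compound 3 remains in compound 4 without the hydroxy group, even with more heavy atoms in its place. Nothing measured here explains why the number holds. Still open, from the compounds shown here alone, is whether a plain amino group or a longer chain on this nitrogen would also leave the number within the scatter.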